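Swapping a Bromophenyl for a Methoxyphenyl

The source may report more compounds than this note shows. Statements on the series, on what has been measured and on what is new or still open speak of the compounds shown alone.

Three compounds sharing one core have been measured in an ADME assay on GES1 cells (Homo sapiens) for inhibition, read by MTT assay, with a stated time of 72 h; a lower number here means a stronger inhibitor, a higher number a weaker inhibitor:
- compound 1, `Cc1cc(Nc2cc(-c3ccccc3)[nH]n2)n2nc(SCc3c(Cl)cccc3Cl)nc2n1`, gives 39600 nM.
- compound 2, `Cc1cc(Nc2cc(-c3cccs3)[nH]n2)n2nc(SCc3ccc(Br)cc3)nc2n1`, gives 38700 nM.
- compound 3, `Cc1cc(Nc2cc(-c3ccccc3)[nH]n2)n2nc(SCc3cccc(Br)c3)nc2n1`, gives > 50000 nM; this is a limit of the assay and not a number.

All three are weak inhibitors. Compound 3 sits at the upper edge of what can be reported, shown by the limit of > 50000 nM in this assay, at which 1 of the 3 values shown sits, so the figures for compound 1 and compound 2 fall at or below its floor without any ordering among the three being established. Within the data shown here, the one step that reaches compound 3, an at least 1.2-fold higher number from compound 1 to compound 3 (0.10 log units; that floor lies within the scatter), does not exceed the usual scatter.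

Compound 4, `COc1ccc(CSc2nc3nc(C)cc(Nc4cc(-c5ccccc5)[nH]n4)n3n2)cc1`, is the unmeasured partner of compound 3. The change is 4-methoxyphenyl in place of 3-bromophenyl on a saturated chain carbon bound to a sulfur. Among the measured compounds shown here, no measured step exchanges a 3-bromophenyl for a 4-methoxyphenyl, so the only guidance is that every substituent tried so far on the saturated chain carbon bound to a sulfur has left inhibition weak, and the step into compound 3 stayed within the scatter. Compound 4 is therefore expected to remain in the same weak range, with an at least 1.1-fold lower number from compound 3 to compound 4 (0.04 log units; that floor lies within the scatter) as the expected step, and may well itself be expected to sit at a limit. The estimate for compound 4 is 45000 nM, between 20000 nM and 100000 nM.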

Compound 4, half-maximal inhibitory concentration: 28200 nM
Estimate against measurement, compound 4: 1.6-fold (0.20 log units) above; the measured number falls inside the stated range.
By their numbers in this assay, from the lowest: compounds 4, 2 and 1 (each within the scatter of the next). At a limit, above all of these: compound 3.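

Compound 4 is the only one shown whose ring on the saturated chain carbon bound to a sulfur carries no halogen, and swapping 3-bromophenyl for 4-methoxyphenyl there gives an at least 1.7-fold lower number from compound 3 to compound 4 (0.24 log units; that floor lies within the scatter) in this assay. Replacing 2,6-dichlorophenyl with the same group gives a 1.4-fold lower number from compound 1 to compound 4 (0.15 log units; within the scatter), so neither step shows that removing the halogens or adding the one hydrogen-bond acceptor counted on 4-methoxyphenyl changes inhibition. The first step is only a floor because compound 3 stands at a limit of the assay and not at a number: the limit of > 50000 nM in this assay, at which 1 of the 4 values shown sits.

Going by these compounds, how far the true value of compound 3 lies from its limit remains open, and with it the real size of the step to compound 4. Every group shown at this position is a substituted phenyl ring, so it is also open whether an amine, a carboxylic acid or a longer chain there would move the number beyond the scatter.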